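Hydroxyalkyl triazole series: working notes toward compound 4

A few compounds are considered here, and "the series" means these few. Any claim that something is new, unique, unknown or untested is made for them only; others in the source may bear on it.

Measured so far:
compound 1 `OCc1cn(CCNc2nonc2/C(=N/O)Nc2ccc(F)c(Br)c2)nn1`, 77 nM
compound 2 `CC(O)c1cn(CCNc2nonc2/C(=N/O)Nc2ccc(F)c(Br)c2)nn1`, 53 nM
compound 3 `CCC(O)c1cn(CCNc2nonc2/C(=N/O)Nc2ccc(F)c(Br)c2)nn1`, 73 nM

All three share one core and differ only in the alkyl group on the carbon that bears the hydroxyl. In an assay on isolated protein for inhibition of Indoleamine 2,3-dioxygenase 1 (Homo sapiens) (on this read-out lower numbers stand for stronger inhibition and higher numbers for weaker inhibition), compound 3 stands second highest of the three numbers; its nearest neighbour is compound 1, with the step from compound 1 to compound 3 being a 1.1-fold lower number from compound 1 to compound 3 (0.02 log units; within the scatter), and its furthest is compound 2, with the step from compound 2 to compound 3 being a 1.4-fold higher number from compound 2 to compound 3 (0.14 log units; within the scatter). The step from compound 1 to compound 2 is a 1.5-fold lower number from compound 1 to compound 2 (0.16 log units; within the scatter). None of these three steps leaves the scatter.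

Compound 4 `CC(C)CC(C)(O)c1cn(CCNc2nonc2/C(=N/O)Nc2ccc(F)c(Br)c2)nn1` carries the change (1-hydroxy-1,3-dimethylbutyl in place of 1-hydroxypropyl on an aromatic carbon). The three measured steps all concern growth of the alkyl group at the hydroxyl-bearing carbon, and each stayed within the scatter, so they bear directly on this step. On that basis no step beyond the scatter is expected in this assay from compound 3 to compound 4, in either direction; the expected step is a 1.0-fold lower number from compound 3 to compound 4 (0.02 log units; within the scatter). Compound 4 is accordingly estimated at 70 nM, with a range from 30 nM to 160 nM.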

Compound 4, half-maximal inhibitory concentration: 51 nM
Compound 4: middle estimate off by 1.4-fold (0.14 log units), on the high side; low and high end bracket the measured number.
By their numbers in this assay, from the lowest: compounds 4, 2, 3 and 1 (each within the scatter of the next).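

In this assay, 1-hydroxy-1,3-dimethylbutyl, with 7 heavy atoms, takes the place of 1-hydroxypropyl, with 4 heavy atoms, and the result is a 1.4-fold lower number from compound 3 to compound 4 (0.16 log units; within the scatter); compared with the other two compounds, the result is a 1.0-fold lower number from compound 2 to compound 4 (0.02 log units; within the scatter) and a 1.5-fold lower number from compound 1 to compound 4 (0.18 log units; within the scatter). For the compounds shown here, this position on the aromatic carbon therefore tolerates, across all four compounds, a branched chain and a hydroxyl-bearing carbon that carries two alkyl groups, which goes further than the single unbranched methyl or ethyl growth seen among the earlier compounds, with no step beyond the scatter so far. No measurement shown gives a reason for this flat response to the size of the group.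

The compounds shown leave open whether any group at this position would leave the scatter, for example a phenyl or cyclohexyl group on the hydroxyl-bearing carbon, or an amine or carboxylic acid in place of the hydroxyl. They also leave open whether a methyl ether of the hydroxyl would keep the number within the scatter of these four compounds.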